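The compounds below may be only part of what the source reports. "The series", "measured", "known", "first", "only" and "open" are said of these compounds alone.

Working notes on the series. The three measured members share one core, shown in compound 1 `O=C(O)C1(Sc2ncnc3ccccc23)CCC1`, compound 2 `O=C(O)C1(Sc2ccnc3cccnc23)CCC1` and compound 3 `Nc1ccc2nccc(SC3(C(=O)O)CCC3)c2c1`, and all were run in an assay on HEK293 cells for inhibition of solute carrier family 22 member 12 (Homo sapiens), read by scintillation counting, with a stated time of 12 min; on this read-out higher numbers stand for weaker inhibition and lower numbers for stronger inhibition. For compound 1 the assay gives only a limit, > 10000 nM. For compound 2 the assay likewise gives only a limit, > 10000 nM. Compound 3 is the single member with a number, 1790 nM, and so stands as the only compound of the shown set with a measurable read-out. Compound 1 and compound 2 sit at the limit (the limit of > 10000 nM in this assay, at which 2 of the 3 values shown sit). Going by the values given here, no two measured compounds differ in just one place, so no measured step within the set can be drawn on.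

Compound 4 `N#CCCc1ccc2nccc(SC3(C(=O)O)CCC3)c2c1` has not yet been measured. It differs from compound 3 in one place: 2-cyanoethyl in place of amino on an aromatic carbon. Without a measured step to lean on, the step from compound 3 to compound 4 in this assay is expected to be modest and toward weaker inhibition, estimated as a 2.0-fold higher number from compound 3 to compound 4 (0.29 log units; within the scatter). Compound 4 is accordingly estimated at 3500 nM, within a range from 900 nM to 14000 nM, with a real chance that the assay again reports only a limit.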

Compound 4, half-maximal inhibitory concentration: 2760 nM
Estimate against measurement, compound 4: 1.3-fold (0.10 log units) above; measured number inside the range.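

In this assay, going by these compounds alone, the one measured step at this aromatic carbon reads a 1.5-fold higher number from compound 3 to compound 4 (0.19 log units; within the scatter), so compound 3 and compound 4 cannot be told apart on this read-out. The exchange removes the hydrogen-bond donor of amino and brings in a nitrile-bearing chain with more heavy atoms, yet the two values stay within the scatter of each other, which shows that, for this pair, a hydrogen-bond donor on this carbon is not needed for a measurable number. With compound 4, the shown set now holds two numbers rather than one, while the remaining two values are still only limits of the assay: the limit of > 10000 nM in this assay, at which 2 of the 4 values shown sit.

The compounds shown leave open what a plain hydrogen, a methoxy group, a carboxamide or a longer chain ending in a nitrile would give on this same carbon, and so whether any group there can move the number beyond the scatter. They also leave open whether 2-cyanoethyl or amino would give a number on the cores of compound 1 and compound 2, and what happens when the carboxylic acid is replaced by an ester or a tetrazole.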